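Benzyl Aryl Swaps on a Shared Amide Core

This account rests on a few compounds, and the source may have more. Where it says the series, first, only, none or still open, it means among the compounds named here.

Compound 1 `COc1ccc(CN2CCC(CCNC(=O)/C=C/c3cc(C(C)(C)C)c(O)c(C(C)(C)C)c3)CC2)cc1`: 61200 nM
Compound 2 `Cc1ccccc1CN1CCC(CCNC(=O)/C=C/c2cc(C(C)(C)C)c(O)c(C(C)(C)C)c2)CC1`: 65300 nM
Compound 3 `CC(C)(C)c1cc(/C=C/C(=O)NCCC2CCN(Cc3ccccc3F)CC2)cc(C(C)(C)C)c1O`: 55900 nM

These three numbers come from a functional assay, read by spectrophotometry, with a stated time of 30 min; on this read-out higher numbers stand for weaker inhibition and lower numbers for stronger inhibition. Compound 2 sits alongside the other two: the step of a 1.1-fold higher number from compound 1 to compound 2 (0.03 log units; within the scatter) and the step of a 1.2-fold lower number from compound 2 to compound 3 (0.07 log units; within the scatter) both lie within the scatter, as does the step of a 1.1-fold lower number from compound 1 to compound 3 (0.04 log units; within the scatter). Compound 4 `CC(C)(C)c1cc(/C=C/C(=O)NCCC2CCN(Cc3ccc(C#N)cc3)CC2)cc(C(C)(C)C)c1O` differs from compound 2 by 4-cyanophenyl in place of 2-methylphenyl on a saturated chain carbon bound to an amine nitrogen in a ring. Going by the values given here, the steps that bear on this are the two earlier aryl swaps on the same saturated chain carbon, a 1.1-fold higher number from compound 1 to compound 2 (0.03 log units; within the scatter) and a 1.1-fold lower number from compound 1 to compound 3 (0.04 log units; within the scatter), neither of which moved the number beyond the scatter. Another aryl group at that place is therefore expected to give no step beyond the scatter, so a 1.1-fold lower number from compound 2 to compound 4 (0.04 log units; within the scatter) is the estimated change. Compound 4 is expected to give 60000 nM in this assay, between 30000 nM and 120000 nM.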

Compound 4, half-maximal inhibitory concentration: 79500 nM
The estimate for compound 4 lay 1.3-fold (0.12 log units) below the measured number; low and high end bracket the measured number.
By their numbers in this assay, from the lowest: compounds 3, 1, 2 and 4 (each within the scatter of the next).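

In this assay, 4-cyanophenyl on this saturated chain carbon stays within the scatter of all three earlier aryl groups (a 1.2-fold higher number from compound 2 to compound 4 (0.09 log units; within the scatter); a 1.4-fold higher number from compound 3 to compound 4 (0.15 log units; within the scatter); a 1.3-fold higher number from compound 1 to compound 4 (0.11 log units; within the scatter)). The tolerance seen so far at this place therefore also covers an aryl group carrying a nitrile, with its triple bond and hydrogen-bond acceptor. Nothing available explains why these numbers stay so close.

The compounds shown leave open whether an aryl group bearing a carboxylic acid or an amine would move the number beyond the scatter. They also leave open whether a cyclohexyl group in place of the aryl ring would do so.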